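A few compounds are considered here, and "the series" means these few. Any claim that something is new, unique, unknown or untested is made for them only; others in the source may bear on it.

The measured compounds:
compound 1, `Fc1ccc(-c2nc3cnc(Nc4ccc(C(F)(F)F)cn4)cc3[nH]2)cc1F`: 6000 nM
compound 2, `FC(F)(F)c1ccc(Nc2cc3[nH]c(C4CCOCC4)nc3cn2)nc1`: 196000 nM
compound 3, `FC(F)(F)c1ccc(Nc2cc3[nH]c([C@H]4CC[C@H](C(F)(F)F)CC4)nc3cn2)nc1`: 200000 nM

In a physicochemical assay for solubility, using the shake flask method, measured as kinetic solubility, with a stated time of 20 h, at pH 2 (a higher number here means a more soluble compound, a lower number a less soluble compound), compound 1 stands lowest of the three numbers. The step of a 33-fold higher number from compound 1 to compound 2 (1.51 log units; beyond the scatter) and the step of a 33-fold higher number from compound 1 to compound 3 (1.52 log units; beyond the scatter) are both large, while a 1.0-fold higher number from compound 2 to compound 3 (0.01 log units; within the scatter). Both large steps exchange the 3,4-difluorophenyl on the shared core for a saturated ring and leave the rest of the molecule untouched.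

Compound 4, `O=C(O)c1ccc(Nc2cc3[nH]c(-c4ccc(F)c(F)c4)nc3cn2)nc1`, keeps the 3,4-difluorophenyl of compound 1 and is changed at the other end instead: carboxy in place of trifluoromethyl on an aromatic carbon. Within the data shown here, no measured pair shows this exchange, and none shows any change at that ring, so the two large steps from compound 1 tell nothing directly about it; they only show that compound 1 sits at the low end of what this set has reached in this assay. With nothing to rest on but the value of compound 1, the expected step is a 1.7-fold higher number from compound 1 to compound 4 (0.22 log units; within the scatter), set near none beyond the scatter and carrying a wide range on both sides. Compound 4 is therefore estimated at 10000 nM, within 1500 nM to 70000 nM.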

Compound 4, solubility: 11000 nM
Beside the measured number, compound 4's estimate is 1.1-fold (0.04 log units) below it; low and high end bracket the measured number.
By their numbers in this assay, from the lowest: compounds 1 and 4 (each within the scatter of the next); then compounds 2 and 3 (each within the scatter of the next).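

In this assay, among these compounds, the earlier compounds varied only the group that replaces 3,4-difluorophenyl, so compound 4 gives the first reading at the other end of the molecule, on an aromatic carbon of a six-membered aromatic ring with 1 nitrogen, two atoms from the ring nitrogen. With the 3,4-difluorophenyl kept, carboxy in place of trifluoromethyl gives a 1.8-fold higher number from compound 1 to compound 4 (0.26 log units; within the scatter) and so does not move the number beyond the scatter, whereas the exchange at the other end gave a 33-fold higher number from compound 1 to compound 2 (1.51 log units; beyond the scatter) and was large. No measurement at hand accounts for this contrast between the two ends of the molecule.

On these data alone, whether carboxy in place of trifluoromethyl gives a similarly small step with a saturated ring at the other end, as in compound 2 or compound 3, remains open. Also open, as far as these compounds go, is what an amine, a primary amide or a nitrile would give at this place in this assay, so this single exchange does not describe the position as a whole.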